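The compounds below may be only part of what the source reports. "The series", "measured", "known", "first", "only" and "open" are said of these compounds alone.

Working notes on the series in an ADME assay on Vero cells (Chlorocebus sabaeus) for cytotoxicity, read by MTT assay, with a stated time of 72 h; a higher number here means that more compound is tolerated, a lower number that less compound is tolerated. Compound 1 (`COc1ccc(/C=C(\C)C(=O)/C=C/c2cccc(Br)c2)cc1`) gives 153000 nM, compound 2 (`COc1ccc(/C=C(\C)C(=O)/C=C/c2ccccc2Cl)cc1`) gives 74300 nM and compound 3 (`COc1ccc(/C=C(\C)C(=O)/C=C/c2ccc(F)cc2)cc1`) gives 68100 nM. Compound 3 stands at the shared low end of these three numbers, and the two lower members are level: a 1.1-fold lower number from compound 2 to compound 3 (0.04 log units; within the scatter). The top member stands apart, with a 2.2-fold lower number from compound 1 to compound 3 (0.35 log units; beyond the scatter) and a 2.1-fold lower number from compound 1 to compound 2 (0.31 log units; beyond the scatter), both modest.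

Compound 4 (`COc1ccc(/C=C(\C)C(=O)/C=C/c2ccc(Br)cc2)cc1`) has not been measured. Its difference from compound 3 is bromo in place of fluoro on an aromatic carbon, para to a large group, which reads as 4-fluorophenyl to 4-bromophenyl. Going by the values given here, no measured step makes this exact exchange. Among the compounds with values here, the closest evidence is compound 1, the only measured bromo member, and a 2.2-fold lower number from compound 1 to compound 3 (0.35 log units; beyond the scatter) is the step that bears most directly, although that bromo does not form a 4-bromophenyl group. This single comparison supports only a weak expectation of a small rise in this assay, probably not beyond the scatter. The estimated change is a 1.5-fold higher number from compound 3 to compound 4 (0.19 log units; within the scatter). For compound 4 the expected value is 105000 nM, with an estimated range from 55000 nM to 200000 nM.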

Compound 4, half-maximal cytotoxic concentration: 31200 nM
Beside the measured number, compound 4's estimate is 3.4-fold (0.53 log units) above it, outside the stated range (below it).
By their numbers in this assay, from the lowest: compound 4; then compounds 3 and 2 (each within the scatter of the next); then compound 1.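

In this assay, going by these compounds alone, the exchange of fluoro for bromo on an aromatic carbon, para to a large group, gives a 2.2-fold lower number from compound 3 to compound 4 (0.34 log units; beyond the scatter) and so moves the number down, a direct reading of this position that the earlier compounds could not give. The two bromo members now stand at opposite ends of the series: 4-bromophenyl in place of 3-bromophenyl gives a 4.9-fold lower number from compound 1 to compound 4 (0.69 log units; beyond the scatter) as the largest step among these compounds, so among these two members the mere presence of bromo does not set the number and its place on the ring goes with a clear difference. The 4-bromophenyl group also separates from the 2-chlorophenyl group, with a 2.4-fold lower number from compound 2 to compound 4 (0.38 log units; beyond the scatter) placing compound 4 alone at the low end of the series, and nothing available here accounts for this shift.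

The compounds shown leave open whether the downward move from fluoro to bromo at this position is a trend across the halogens, since a 4-chlorophenyl member is absent from this set. They also leave open how a group of a different kind at the same position, such as an amine, a carboxylic acid or a longer chain, would stand against compound 3 and compound 4.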